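The source may hold more compounds than are shown below. What is called first, only, known or untested is meant among the compounds shown, and "the series" means these compounds.

Measured compounds:
- compound 1, `O=c1oc2c(O)cccc2cc1-c1ccc(Br)cc1`: in an assay on CHO cells for displacement of a labelled ligand from adenosine receptor A3 (Homo sapiens), read by radioligand binding (on this read-out higher numbers stand for weaker inhibition and lower numbers for stronger inhibition), compound 1 gives 258 nM
- compound 2, `O=c1oc2c(O)cccc2cc1-c1ccccc1`: in this assay compound 2 gives 5090 nM

Among the measured compounds shown here, compound 2 stands at the highest of the two numbers in this assay; its nearest neighbour is compound 1, and the only measured step in the set is a 20-fold higher number from compound 1 to compound 2 (1.30 log units; beyond the scatter), a large one.

Compound 3, `O=c1oc2c(O)c(O)ccc2cc1-c1ccccc1`, is not yet measured. It differs from compound 2 by hydroxy in place of hydrogen on an aromatic carbon. For the measured compounds named here, no measured step in the set touches this part of the shared core: the single step, a 20-fold higher number from compound 1 to compound 2 (1.30 log units; beyond the scatter), concerns the phenyl substituent and not the hydroxy-bearing ring, so it gives no direct guide to the size or direction of the change from compound 2 to compound 3. Going by the values given here, with no step bearing on it, the expectation for this assay is a step of no clear size beyond the scatter, with wide uncertainty in either direction.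

Compound 3 is therefore estimated at 5000 nM, with a range from 1500 nM to 16000 nM, which corresponds to an expected step of a 1.0-fold lower number from compound 2 to compound 3 (0.01 log units; within the scatter).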

Compound 3, inhibition constant: 3850 nM
Compound 3: the middle estimate sits 1.3-fold (0.11 log units) above what was measured; the measured number falls inside the stated range.
By their numbers in this assay, from the lowest: compound 1; then compounds 3 and 2 (each within the scatter of the next).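

In this assay the hydroxy in place of hydrogen, set on an aromatic carbon ortho to a hydroxy group, gives a 1.3-fold lower number from compound 2 to compound 3 (0.12 log units; within the scatter) and so leaves the number of compound 3 within the scatter of that of compound 2. Among the compounds shown here, this position of the shared core therefore accepts a second hydroxy without a read-out change in this unbrominated pair, whereas the only earlier step, a 20-fold higher number from compound 1 to compound 2 (1.30 log units; beyond the scatter), lies at a different place and is large. Of the two single changes now read, only the bromo one moves the number beyond the scatter, and no available evidence accounts for the difference between these two steps.

Going by these compounds, whether the added hydroxy would be equally silent on the core of compound 1, with the bromo present, remains open. Also open, on these data alone, is whether this position stays as undemanding with other groups in place of the hydroxy, such as a methoxy, an amine or a carboxylic acid, since one hydroxy alone does not define what the position will accept.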